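Aryl swap on the chain carbon of compound 2

A few compounds are considered here, and "the series" means these few. Any claim that something is new, unique, unknown or untested is made for them only; others in the source may bear on it.

Three compounds of the shared core have numbers in an assay on isolated protein for inhibition of retinal dehydrogenase 2 (Homo sapiens); a higher number here means a weaker inhibitor, a lower number a stronger inhibitor. Compound 1 `Cn1ncc2c(=O)n(-c3ccccc3)c(COc3cccc(F)c3)nc21` gives 1770 nM, compound 3 `O=c1c2cncn2nc(SCc2cccc(F)c2)n1-c1ccccc1` gives 1600 nM, and compound 2 `CC(Sc1nc2c(cnn2C)c(=O)n1-c1ccccc1)c1ccccn1` gives 63 nM, the lowest of the three and beyond the scatter against both others. Compound 4 `CC(Sc1nc2c(cnn2C)c(=O)n1-c1ccccc1)c1cccc(O)c1` is not yet measured; it differs from compound 2 by 3-hydroxyphenyl in place of pyridin-2-yl on a saturated chain carbon bound to a saturated chain carbon and a sulfur. Going by the values given here, no measured pair in this set isolates such a change, so its size is open. The expected step, a 3.5-fold higher number from compound 2 to compound 4 (0.54 log units; beyond the scatter), is a moderate loss beyond the scatter, because compound 2 already stands at 63 nM, the low end of the set. Compound 4 is estimated at 220 nM in this assay, with a range from 60 nM to 800 nM.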

Compound 4, half-maximal inhibitory concentration: 100 nM
Compound 4: middle estimate off by 2.2-fold (0.34 log units), on the high side; the range from low to high includes it.
By their numbers in this assay, from the lowest: compounds 2 and 4 (each within the scatter of the next); then compounds 3 and 1 (each within the scatter of the next).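

In this assay, going by these compounds alone, this is the first pair that isolates a change at this position (a 1.6-fold higher number from compound 2 to compound 4 (0.20 log units; within the scatter)), and it does not separate 3-hydroxyphenyl from pyridin-2-yl. On this saturated chain carbon, a six-membered aromatic ring of carbon only with a hydroxyl group therefore sits within the scatter of a ring with one ring nitrogen. No outside evidence bears on this result.

Still open, going by these compounds, is how plain phenyl, or an amine or carboxylic acid in place of the hydroxyl, would read here. Also open, on these data alone, is what happens if the methyl on the chain carbon is removed.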